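This account rests on a few compounds, and the source may have more. Where it says the series, first, only, none or still open, it means among the compounds named here.

Compound 1 `Cc1cc(C#N)cc(-c2c(C)nn(-c3nc(-c4ccc(Cl)c(Cl)c4)c(SC(C)C)s3)c2C(=O)O)c1` in a functional assay on BJAB cells (Homo sapiens) for antiproliferative activity, with a stated time of 4 days (on this read-out lower numbers stand for an effect already at smaller amounts and higher numbers for an effect only at larger amounts of compound), gives 4800 nM.
Compound 2 `Cc1nn(-c2nc(-c3ccc(Cl)c(Cl)c3)c(SC(C)C)s2)c(C(=O)O)c1-c1cnccn1` in this assay gives 14000 nM.

Among the compounds with values here, compound 2 stands at the higher of the two numbers, so its effect appears only at the larger amount; its sole neighbour on this read-out is compound 1, which gives 4800 nM. Within the data shown here, the single measured step, a 2.9-fold higher number from compound 1 to compound 2 (0.46 log units; beyond the scatter), shows that the group on this carbon of the shared core shifts the read-out by a modest but real amount, with a ring bearing two hetero atoms giving the weaker result.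

Compound 3 `CNc1cc(-c2c(C)nn(-c3nc(-c4ccc(Cl)c(Cl)c4)c(SC(C)C)s3)c2C(=O)O)ccn1` carries the change (2-(methylamino)pyridin-4-yl in place of pyrazin-2-yl on an aromatic carbon). Among the measured compounds shown here, only that one step bears on it, and only loosely: the incoming group again has a single six-membered aromatic ring, now with 1 hetero atom and a methylamino group, so it resembles neither the group of compound 2 nor that of compound 1 closely. A move back toward the smaller amounts seems plausible, though a result within the scatter of compound 2 cannot be ruled out.

Compound 3 is therefore expected to give about 6000 nM, with a range from 2000 nM to 18000 nM.

The expected step is a 2.3-fold lower number from compound 2 to compound 3 (0.37 log units; beyond the scatter), a modest shift toward smaller amounts of compound.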

Compound 3, half-maximal effective concentration: 18000 nM
Beside the measured number, compound 3's estimate is 3.0-fold (0.48 log units) below it; the range from low to high includes it.
By their numbers in this assay, from the lowest: compound 1; then compounds 2 and 3 (each within the scatter of the next).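

In this assay the exchange of pyrazin-2-yl for 2-(methylamino)pyridin-4-yl gives a 1.3-fold higher number from compound 2 to compound 3 (0.11 log units; within the scatter) and so does not separate the two groups on this read-out, even though the entering group carries a hydrogen-bond donor that pyrazin-2-yl lacks. The comparison with the phenyl compound gives a 3.8-fold higher number from compound 1 to compound 3 (0.57 log units; beyond the scatter) and is clearer, so the higher number seen for compound 2 is no longer a single case: among these three compounds, both groups with a hetero atom in the ring give higher numbers than 3-cyano-5-methylphenyl, and none goes against this. No measurement shown here accounts for these results.

As far as these compounds go, what remains open is which feature of 3-cyano-5-methylphenyl matters, since it differs from the other two groups in its ring atoms and in its substituents at once. A plain phenyl ring, or a phenyl ring carrying a methylamino group, would help to tell whether the ring nitrogen or the groups attached to the ring set the read-out at this position.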